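Nitro to chloro on the pendant phenyl: cytotoxicity note

A few compounds are considered here, and "the series" means these few. Any claim that something is new, unique, unknown or untested is made for them only; others in the source may bear on it.

In an ADME assay on MT4 cells (Homo sapiens) for cytotoxicity, read by MTT assay, with a stated time of 5 days (on this read-out lower numbers stand for higher toxicity in this test and higher numbers for lower toxicity in this test), compound 3 `COc1ccc2nc(Nn3c(-c4ccc([N+](=O)[O-])cc4)nnc3-c3cccnc3)sc2c1` gives 12.9 ug/mL. That number is not set apart from compound 1 `O=[N+]([O-])c1ccc(-c2nnc(-c3cccnc3)n2Nc2nc3ccc(Br)cc3s2)cc1`, which gives 13.2 ug/mL, while compound 2 `Cc1ccc2nc(Nn3c(-c4ccc([N+](=O)[O-])cc4)nnc3-c3cccnc3)sc2c1`, at 64.4 ug/mL, stands off from both. The measured steps read a 5.0-fold lower number from compound 2 to compound 3 (0.70 log units; beyond the scatter), a 4.9-fold higher number from compound 1 to compound 2 (0.69 log units; beyond the scatter) and a 1.0-fold lower number from compound 1 to compound 3 (0.01 log units; within the scatter). Compound 4 `COc1ccc2nc(Nn3c(-c4ccc(Cl)cc4)nnc3-c3cccnc3)sc2c1` differs from compound 3 by chloro in place of nitro on an aromatic carbon. None of the three measured steps touches this position; all of them sit on the shared core, so there is no direct guide to the size of this change. On that basis the step from compound 3 is expected to stay within the scatter, a 1.0-fold higher number from compound 3 to compound 4 (0.00 log units; within the scatter). For compound 4 the expected value in this assay is 13 ug/mL, within a range from 5 ug/mL to 35 ug/mL.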

Compound 4, half-maximal cytotoxic concentration: 66.9 ug/mL
Compound 4: the middle estimate sits 5.1-fold (0.71 log units) below what was measured; the measured number lies above the stated range.
By their numbers in this assay, from the lowest: compounds 3 and 1 (each within the scatter of the next); then compounds 2 and 4 (each within the scatter of the next).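

Chloro in place of nitro gives a 5.2-fold higher number from compound 3 to compound 4 (0.71 log units; beyond the scatter) in this assay and so shows that this position, not only the shared core, can move the number. The direction is towards lower toxicity in this test. No measurement shown here offers an explanation for the step.

Going by these compounds, whether the shift comes from losing nitro or from gaining chloro stays open, since only these two groups appear at this position. Also open, on these data alone, are how an amine or a carboxylic acid would read here and whether the chloro step carries over to compound 1 and compound 2.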